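The source may report more compounds than this note shows. Statements on the series, on what has been measured and on what is new or still open speak of the compounds shown alone.

Measured so far in a functional assay on KB cells (Homo sapiens) for antiproliferative activity, read by sulforhodamine B assay, with a stated time of 3 days; on this read-out higher numbers stand for an effect only at larger amounts of compound and lower numbers for an effect already at smaller amounts:
- compound 1 `CCC1=C(O)c2c(oc(-c3ccc(C(C)C)cc3)cc2=O)C(CC)(CC)C1=O`: 8.13 uM
- compound 2 `CCC1=C(O)c2c(oc(-c3ccc(CC(C)C)cc3)cc2=O)C(CC)(CC)C1=O`: 29.3 uM
- compound 3 `CCC1=C(O)c2c(oc(-c3ccc(OC)cc3)cc2=O)C(CC)(CC)C1=O`: 17.7 uM

Compound 1 has the lowest number of the three. The next compound is compound 4 `CCOc1ccc(-c2cc(=O)c3c(o2)C(CC)(CC)C(=O)C(CC)=C3O)cc1`, which differs from compound 1 as follows: ethoxy in place of isopropyl on an aromatic carbon. The closest measured change is methoxy in place of isopropyl, a modest step: a 2.2-fold higher number from compound 1 to compound 3 (0.34 log units; beyond the scatter). Isobutyl in place of isopropyl is also modest: a 3.6-fold higher number from compound 1 to compound 2 (0.56 log units; beyond the scatter). The remaining comparison stays within the scatter: a 1.7-fold lower number from compound 2 to compound 3 (0.22 log units; within the scatter). Only these two replacements of isopropyl are available, and both raised the number, so a modest upward step is expected in this assay. The expected step is a 2.1-fold higher number from compound 1 to compound 4 (0.32 log units; beyond the scatter). The estimated value for compound 4 is 17 uM, with an expected range of 8 uM to 36 uM.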

Compound 4, concentration for half-maximal effect: > 52.4 uM
Compound 4: only a limit was reported (the forecaster's own chance of this, stated with the estimate: 3%); middle value at least 3.0-fold (0.48 log units) away from the limit.
By their numbers in this assay, from the lowest: compound 1; then compounds 3 and 2 (each within the scatter of the next). At a limit, above all of these: compound 4.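

In this assay compound 4 gives a limit, not a number: (the limit of > 52.4 uM in this assay, at which 1 of the 4 values shown sits). Ethoxy is not interchangeable with methoxy at this position: one added methyl gives an at least 2.9-fold higher number from compound 3 to compound 4 (0.47 log units; beyond the scatter) and the swap from isopropyl gives an at least 6.4-fold higher number from compound 1 to compound 4 (0.80 log units; beyond the scatter) which exceeds the step seen for either earlier replacement. Against isobutyl the comparison gives only an at least 1.7-fold higher number from compound 2 to compound 4 (0.25 log units; that floor lies within the scatter) so that gap stays unsettled.

Open, going by these compounds, is the true value of compound 4. Also open, on these data alone, is how a hydroxyl, an amine or a longer alkoxy chain on this aromatic carbon would compare with isopropyl.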